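The compounds below may be only part of what the source reports. "The series", "measured", "known", "first", "only" and "open" are said of these compounds alone.

In an ADME assay on THP-1 cells (Homo sapiens) for cytotoxicity, read by MTT assay, with a stated time of 72 h (on this read-out higher numbers stand for an effect only at larger amounts of compound and lower numbers for an effect already at smaller amounts), compound 1 `O=c1nc(-c2ccccc2)c2cc(-c3cnc4ccccc4c3)ccc2[nH]1` gives > 50000 nM as its reading, which is a limit of the assay and not a number. Compound 2 `O=c1nc(-c2ccccc2)c2cc(-c3ccccc3F)ccc2[nH]1` gives 50000 nM as a true number, the only one so far in this small set. Compound 3 `O=c1nc(-c2ccccc2)c2cc(-c3cn[nH]c3)ccc2[nH]1` differs from compound 2 in one place: 1H-pyrazol-4-yl stands in place of 2-fluorophenyl on an aromatic carbon 1H-pyrazol-4-yl in place of 2-fluorophenyl on an aromatic carbon and the rest of the structure stays the same. For the measured compounds named here, no measured step yet shows what such a swap does in this assay so no shift beyond the usual scatter is expected. Going by the values given here, that expectation starts from compound 2 at 50000 nM as the one number available. The expected change is a 1.3-fold lower number from compound 2 to compound 3 (0.10 log units; within the scatter) and it leans only slightly toward lower numbers. For compound 3 the estimate is 40000 nM with an expected range from 15000 nM to 50000 nM as its upper end.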

Compound 3, half-maximal effective concentration: > 50000 nM
Compound 3: a limit, no number; the forecaster's own chance of this, stated with the estimate: 55%; middle value at least 1.2-fold (0.09 log units) from the limit.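

In this assay putting 1H-pyrazol-4-yl in place of 2-fluorophenyl on this aromatic carbon gives a number no lower from compound 2 to compound 3 (the limit leaves the size open) as the first step readable at this position, so a five-membered ring with a hydrogen-bond donor and acceptor does not move the reading toward lower numbers. Compound 3 reads > 50000 nM as a limit of the assay and not a number. How far the reading rises, if it rises at all, cannot be told because the value sits at the ceiling of the assay: the limit of > 50000 nM in this assay, at which 2 of the 3 values shown sit.

On these data alone, whether an amine, a carboxylic acid or a longer chain on this carbon would bring the reading to lower numbers stays open. Also open, as far as these compounds go, is whether changes to the phenyl group elsewhere on the shared core would alter the reading.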